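Thiadiazole for thiazole on a sulfonamide nitrogen

A few compounds are considered here, and "the series" means these few. Any claim that something is new, unique, unknown or untested is made for them only; others in the source may bear on it.

Of the compounds shown here, three built on the same core have been tested in an ADME assay on HEK293-A cells for inhibition of sodium channel protein type 1 subunit alpha/beta-1/beta-2 (Homo sapiens), read by patch clamp; a lower number here means a stronger inhibitor, a higher number a weaker inhibitor. Compound 1 `Cn1nccc1[C@H]1CCC[C@@H]1Oc1cc(F)c(S(=O)(=O)Nc2nccs2)cc1F` is the only one with a numerical result: in this assay compound 1 gives 13000 nM. Compound 2 `Cn1nccc1[C@H]1CCC[C@@H]1Oc1ccc(S(=O)(=O)Nc2ccncn2)c(F)c1F` reaches only the limit of the assay, with > 100000 nM. Compound 3 `Cn1nccc1[C@H]1CCC[C@@H]1Oc1c(F)cc(S(=O)(=O)Nc2ccncn2)cc1F` likewise stops at the limit, with > 100000 nM. So compound 1 stands alone as the one measurable inhibitor among the three, and the limit of > 100000 nM in this assay, at which 2 of the 3 values shown sit, marks where the other two sit.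

Compound 4 `Cc1nsc(NS(=O)(=O)c2cc(F)c(O[C@H]3CCC[C@@H]3c3ccnn3C)cc2F)n1` has not yet been measured. It differs from compound 1 in one place: 3-methyl-1,2,4-thiadiazol-5-yl in place of 1,3-thiazol-2-yl on a sulfonamide nitrogen. Within the data shown here, no pair of measured compounds shows what such a change does here, so no measured step can guide the expectation directly. The expected step from compound 1 to compound 4 in this assay is a 2.6-fold lower number from compound 1 to compound 4 (0.41 log units; beyond the scatter), a modest move toward stronger inhibition that may only just clear the usual scatter. Compound 4 is therefore estimated at 5000 nM, with a likely range from 1500 nM to 20000 nM.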

Compound 4, half-maximal inhibitory concentration in the sodium channel protein type 1 subunit alpha/beta-1/beta-2 assay: > 100000 nM
Compound 4 ended at the assay's limit; the forecaster's own chance of this, stated with the estimate: 5%; middle value at least 20-fold (1.30 log units) from the limit.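

In the sodium channel protein type 1 subunit alpha/beta-1/beta-2 assay, putting 3-methyl-1,2,4-thiadiazol-5-yl in place of 1,3-thiazol-2-yl on a sulfonamide nitrogen gives an at least 7.6-fold higher number from compound 1 to compound 4 (0.88 log units; beyond the scatter), so this position is sensitive to the change and the measurable inhibition of compound 1 does not survive it. From the compounds shown here alone, the result for compound 4 is a limit of the assay and not a number, so the full size of the step stays unknown. In a physicochemical assay for solubility, read by HPLC, measured as thermodynamic solubility, with a stated time of 4 h, at pH 6.8 (on this read-out lower numbers stand for lower solubility and higher numbers for higher solubility), compound 1 gives 250000 nM and compound 4 gives 1800000 nM, a gap beyond the usual scatter.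

The change adds a methyl and alters the ring in one move, so the compounds shown cannot separate the two. A plain 1,2,4-thiadiazol-5-yl or a methyl-bearing 1,3-thiazol-2-yl on the same sulfonamide nitrogen would tell these contributions apart.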